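Swapping a thiocarbamate for a difluoroethyl amide

This account rests on a few compounds, and the source may have more. Where it says the series, first, only, none or still open, it means among the compounds named here.

Compound 1 `Cc1nc(S(C)(=O)=O)ccc1Oc1ncnc(OC2CCN(C(=O)OC(C)F)CC2)c1F`: 315 nM
Compound 2 `Cc1nc(S(C)(=O)=O)ccc1Oc1ncnc(OC2CCN(C(=S)OC(C)C)CC2)c1F`: 1050 nM

Of the compounds shown here, two have been measured in a functional assay on isolated protein for inhibition of Glucose-dependent insulinotropic receptor (Rattus norvegicus), read by HTRF and cAMP accumulation; a lower number here means that less compound is needed, a higher number that more compound is needed for the effect. Compound 1 gives 315 nM and compound 2 gives 1050 nM, so compound 2 stands at the higher of the two numbers, with a 3.3-fold higher number from compound 1 to compound 2 (0.52 log units; beyond the scatter). The unmeasured compound 3 `Cc1nc(S(C)(=O)=O)ccc1Oc1ncnc(OC2CCN(C(=O)C(C)(F)F)CC2)c1F` differs from compound 2 by a group of 6 heavy atoms (3 carbon, 1 oxygen, 2 fluorine; no ring) in place of a group of 6 heavy atoms (4 carbon, 1 oxygen, 1 sulfur; no ring), on an amine nitrogen in a ring on the piperidine nitrogen. For the measured compounds named here, the only measured step, a 3.3-fold higher number from compound 1 to compound 2 (0.52 log units; beyond the scatter), replaced a fluorinated carbamate with a thiocarbamate; the step to compound 3 reverses the sulfur-for-oxygen part of that change and restores fluorine, which makes compound 3 look closer to compound 1 than to compound 2. A return toward the number of compound 1 is therefore expected, giving an estimated 3.0-fold lower number from compound 2 to compound 3 (0.48 log units; beyond the scatter). Compound 3 is estimated at 350 nM, within a range of 120 nM to 1000 nM.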

Compound 3, half-maximal effective concentration: 239 nM
Compound 3: the middle estimate sits 1.5-fold (0.17 log units) above what was measured; low and high end bracket the measured number.
By their numbers in this assay, from the lowest: compounds 3 and 1 (each within the scatter of the next); then compound 2.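

In this assay, replacing the thiocarbamate on the ring nitrogen with (1,1-difluoroethyl)carbonyl gives a 4.4-fold lower number from compound 2 to compound 3 (0.64 log units; beyond the scatter), showing that this position tolerates an amide as well as a carbamate. On the carbonyl carbon, the group holding an oxygen and a fluorine can give way to one holding two fluorines and no oxygen with no clear change in the number, with a 1.3-fold lower number from compound 1 to compound 3 (0.12 log units; within the scatter). Nothing measured here explains why these groups give these numbers.

Several atoms change at once in these steps, so the part played by the sulfur remains open, and the isopropyl carbamate with a carbonyl oxygen would help to separate it. From the compounds shown here alone, the role of fluorine also remains open, and a propionyl amide, which carries no fluorine, would test it directly.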